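Removing the Methoxy Group from the Best Compound So Far

The source may report more compounds than this note shows. Statements on the series, on what has been measured and on what is new or still open speak of the compounds shown alone.

Measured compounds:
Compound 1, `CNC(=O)[C@@H](c1ccccc1)N1CCn2c(COC)nc(Cl)c2[C@@H]1CCc1ccc(C(F)(F)F)cc1`: 1650 nM
Compound 2, `CCc1nc(I)c2n1CCN([C@@H](C(=O)NC)c1ccccc1)C2CCc1ccc(C(F)(F)F)cc1`: 717 nM
Compound 3, `CCc1nc(OC)c2n1CCN([C@@H](C(=O)NC)c1ccccc1)C2CCc1ccc(C(F)(F)F)cc1`: 134 nM

In a functional assay on CHO cells for antagonist activity at Orexin/Hypocretin receptor type 1 (Homo sapiens), read by FLIPR and calcium flux (on this read-out lower numbers stand for stronger inhibition and higher numbers for weaker inhibition), compound 3 gives the lowest number of the three measured compounds, with compound 2 next at 717 nM and compound 1 furthest away at 1650 nM. Both gaps lie beyond the scatter, so compound 3 is the strongest inhibitor among the measured set.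

Compound 4, `CCc1ncc2n1CCN([C@@H](C(=O)NC)c1ccccc1)C2CCc1ccc(C(F)(F)F)cc1`, is compound 3 with one change: hydrogen in place of methoxy on an aromatic carbon. Among the measured compounds shown here, only one measured step concerns this same position of the shared core: a 5.4-fold lower number from compound 2 to compound 3 (0.73 log units; beyond the scatter). That step swapped one substituent for another, and neither of its partners is hydrogen, so it shows that the group at this carbon matters for the read-out but does not say what a bare carbon does. Compound 1 carries a chloro at this position, yet it also differs from compound 3 elsewhere, so its value cannot be tied to this carbon alone.

Given that the single relevant step was modest and that removing the group altogether is a different kind of change, a modest rise in the number is expected for compound 4, with an expected step of a 2.6-fold higher number from compound 3 to compound 4 (0.42 log units; beyond the scatter). Compound 4 is therefore estimated at 350 nM, within a range from 100 nM to 1200 nM.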

Compound 4, half-maximal inhibitory concentration: 10000 nM
For compound 4 the middle estimate is 29-fold (1.46 log units) below the measured one; measured number outside the range, above it.
By their numbers in this assay, from the lowest: compound 3; then compound 2; then compound 1; then compound 4.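

In this assay a bare carbon at this position does far worse than either substituent tested: removing the methoxy group gives a 75-fold higher number from compound 3 to compound 4 (1.87 log units; beyond the scatter) and removing the iodo group gives a 14-fold higher number from compound 2 to compound 4 (1.14 log units; beyond the scatter). The earlier step, a 5.4-fold lower number from compound 2 to compound 3 (0.73 log units; beyond the scatter), only ranked two substituents against each other, whereas these new steps show that among these three compounds, having either group on this aromatic carbon gives a much lower number than having hydrogen there, with methoxy giving the lowest number of the three. No measurement offered here bears on why hydrogen falls so far behind, so the size of the loss stands as an observation without an explanation.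

The compounds shown leave open how an amine, a nitrile or a longer ether such as ethoxy would compare with methoxy at this carbon, so it remains unknown whether methoxy is close to the best choice here or simply better than iodo and hydrogen. Compound 1 carries a chloro group at this carbon but also differs elsewhere in the molecule, so chloro cannot be placed in this order.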